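The source may hold more compounds than are shown below. What is called first, only, known or untested is meant among the compounds shown, and "the series" means these compounds.

Measured compounds:
- compound 1 `C=C(Br)C(=O)Nc1cccc(/C=C/C(=O)Nc2cccc3ccccc23)c1` gives 1400 nM
- compound 2 `C=C(Br)C(=O)Nc1cccc(/C=C/C(=O)Nc2ccc(F)cc2)c1` gives 16800 nM
- compound 3 `C=C(Br)C(=O)Nc1cccc(/C=C/C(=O)Nc2cccc(F)c2)c1` gives 1200 nM

These values come from a functional assay on HeLa cells (Homo sapiens) for inhibition, read by MTT assay, with a stated time of 72 h; a lower number here means a stronger inhibitor, a higher number a weaker inhibitor. Compound 2 has the highest number of the three, 16800 nM, which makes it the weakest inhibitor here. Compound 4 `C=C(Br)C(=O)Nc1cccc(/C=C/C(=O)Nc2ccc(OC(F)(F)F)cc2)c1` has not yet been measured. It differs from compound 2 in one place: trifluoromethoxy in place of fluoro on an aromatic carbon. In words, trifluoromethoxy stands in place of fluoro on an aromatic carbon.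

For the measured compounds named here, only one measured step comes close to this change: a 14-fold lower number from compound 2 to compound 3 (1.15 log units; beyond the scatter). That large step moves the fluoro group rather than replacing it, so it offers only a loose guide, but it shows that a single change in this region can matter greatly. Compound 1, which has no fluoro group, gives 1400 nM, also far lower than compound 2. Going by the values given here, a moderate drop therefore seems more likely than a rise, though no measured step tests the new group. The expected change is a 3.4-fold lower number from compound 2 to compound 4 (0.53 log units; beyond the scatter). For compound 4 the estimate is 5000 nM, with an expected range from 1200 nM to 18000 nM.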

Compound 4, half-maximal inhibitory concentration: 29000 nM
Estimate against measurement, compound 4: 5.8-fold (0.76 log units) below; the measured number lies above the stated range.
By their numbers in this assay, from the lowest: compounds 3 and 1 (each within the scatter of the next); then compounds 2 and 4 (each within the scatter of the next).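

In this assay, putting trifluoromethoxy in place of fluoro on this aromatic carbon gives a 1.7-fold higher number from compound 2 to compound 4 (0.24 log units; within the scatter) and so leaves the two compounds indistinguishable. The earlier compounds shown here showed that this region can respond strongly, with a 14-fold lower number from compound 2 to compound 3 (1.15 log units; beyond the scatter) when the 3-fluorophenyl replaced the 4-fluorophenyl; here, by contrast, a group of five heavy atoms that adds a hydrogen-bond acceptor replaces a single fluorine without a change beyond the scatter. Nothing measured here explains this result.

Still open, as far as these compounds go, is whether a different kind of group at this place, such as an amine or a carboxylic acid, would also leave the number within the scatter. It is also unknown whether trifluoromethoxy would give a similar number where compound 3 carries its fluoro.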